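The compounds below may be only part of what the source reports. "The series", "measured", "known", "first", "only" and "open" are said of these compounds alone.

In a functional assay on A549 cells (Homo sapiens) for cytotoxicity, read by MTT assay, with a stated time of 48 h (a higher number here means a weaker inhibitor, a lower number a stronger inhibitor), compound 1 `OC[C@@H]1C[C@H](CO)[C@@H]2C(c3ccc(Cl)cc3)=NO[C@H]12` gives > 50 ug/mL, which is a limit and not a number. Compound 2 `N#Cc1ccc(C2=NO[C@@H]3[C@H](CO)C[C@H](CO)[C@H]23)cc1` gives > 50 ug/mL, also a limit. Compound 3 `OC[C@@H]1C[C@H](CO)[C@@H]2C(c3ccc4ccccc4c3)=NO[C@H]12` gives > 50 ug/mL, again a limit. Compound 2 therefore has no exact value and shares (the limit of > 50 ug/mL in this assay, at which 3 of the 3 values shown sit). Compound 4 `OC[C@@H]1C[C@H](CO)[C@@H]2C(c3ccc(F)cc3)=NO[C@H]12` differs from compound 2 by one change: fluoro in place of cyano on an aromatic carbon. This places fluoro in place of cyano on an aromatic carbon, para to a large group. Going by the values given here, the only measured step bearing on this is a step that the two limits leave unreadable from compound 1 to compound 2, so it offers no size to carry over. No change in either direction is expected, and the estimated step is a step that the limit leaves unreadable from compound 2 to compound 4. The estimate for compound 4 is 60 ug/mL, with an expected range from 30 ug/mL to 150 ug/mL.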

Compound 4, half-maximal inhibitory concentration: 31.1 ug/mL
For compound 4 the middle estimate is 1.9-fold (0.29 log units) above the measured one; low and high end bracket the measured number.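

Going by these compounds alone, on the aromatic carbon para to a large group, fluoro gives the only exact reading in this assay, so this position can yield a number and not just a limit. Replacing cyano gives an at least 1.6-fold lower number from compound 2 to compound 4 (0.20 log units; that floor lies within the scatter), and replacing chloro gives an at least 1.6-fold lower number from compound 1 to compound 4 (0.20 log units; that floor lies within the scatter). The other values shown are limits and not numbers: the limit of > 50 ug/mL in this assay, at which 3 of the 4 values shown sit.

Going by these compounds, both steps are floors, so their true sizes remain unknown. On these data alone, it also remains open how an amine, a methoxy group or a carboxylic acid at this position would read.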